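The source may hold more compounds than are shown below. What is called first, only, known or untested is meant among the compounds shown, and "the series" means these compounds.

Measured compounds in this series:
- compound 1, `C/C(=N\Nc1nc(-c2ccc(C)cc2)cs1)c1cc2ccccc2o1`: 14300 nM
- compound 2, `CCOC(=O)Cc1csc(N/N=C(\C)c2cc3ccccc3o2)n1`: 9260 nM

In a functional assay on HeLa cells (Homo sapiens) for antiproliferative activity (a higher number here means a weaker inhibitor, a lower number a stronger inhibitor), compound 1 gives 14300 nM, the highest of the two numbers recorded. Compound 2 gives 9260 nM in this assay; the step of a 1.5-fold lower number from compound 1 to compound 2 (0.19 log units; within the scatter) lies within the scatter, so compound 1 and compound 2 cannot be told apart on these numbers.

Compound 3, `C/C(=N\Nc1nc(-c2cc3ccccc3o2)cs1)c1cc2ccccc2o1`, has not yet been measured in this assay. It differs from compound 1 at the same position that separates compound 1 from compound 2: 1-benzofuran-2-yl in place of 4-methylphenyl on an aromatic carbon. Within the data shown here, the only measured step that bears on this position is the one from compound 1 to compound 2, a 1.5-fold lower number from compound 1 to compound 2 (0.19 log units; within the scatter), which is within the scatter. Among the measured compounds shown here, no measured pair exchanges 4-methylphenyl for 1-benzofuran-2-yl, so the expectation rests on that single step alone. On that basis no step beyond the scatter is expected, and the step from compound 1 to compound 3 is estimated as a 1.3-fold lower number from compound 1 to compound 3 (0.11 log units; within the scatter). For compound 3 in this assay the estimated value is 11000 nM, with a range from 3500 nM to 35000 nM.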

Compound 3, half-maximal inhibitory concentration: 24100 nM
For compound 3 the middle estimate is 2.2-fold (0.34 log units) below the measured one; the measured number falls inside the stated range.
By their numbers in this assay, from the lowest: compounds 2, 1 and 3 (each within the scatter of the next, the first and the last beyond it).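

In this assay the step of a 1.7-fold higher number from compound 1 to compound 3 (0.23 log units; within the scatter) shows that 1-benzofuran-2-yl, with two aromatic rings and one hydrogen-bond acceptor, can replace 4-methylphenyl on this aromatic carbon without a change that can be told from the scatter. The position does, however, give its first step beyond the scatter: a 2.6-fold higher number from compound 2 to compound 3 (0.42 log units; beyond the scatter) is modest in size and comes from 1-benzofuran-2-yl in place of (ethoxycarbonyl)methyl, so the group at this place can move the number, whereas compound 1 and compound 2 could not be separated. Nothing at hand gives a measured property of these groups that would account for this step.

Among these compounds, with only three groups seen at this position, it remains open whether a carboxylic acid or a primary amine in place of (ethoxycarbonyl)methyl would give a number clearly apart from that of compound 2. As far as these compounds go, the rest of the shared core is the same in compound 1, compound 2 and compound 3, so how the number responds to a change anywhere else on it also remains open.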